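A few compounds are considered here, and "the series" means these few. Any claim that something is new, unique, unknown or untested is made for them only; others in the source may bear on it.

Of the compounds shown here, two have been measured. Compound 1 `CNCc1cn(S(=O)(=O)c2ccco2)c(-c2cccnc2F)c1F` carries a furan-2-yl on its sulfonyl sulfur, and in a physicochemical assay for lipophilicity, read by HPLC, at pH 7.4 (a lower number here means a more polar compound, a higher number a more lipophilic compound), compound 1 gives 0.2. Compound 2 `CNCc1cn(S(=O)(=O)c2ccccn2)c(-c2cccnc2F)c1F` carries a pyridin-2-yl at the same place, and in this assay compound 2 gives 0.44. For the measured compounds named here, the only step known so far is a number 0.24 log units higher from compound 1 to compound 2 (within the scatter), so the two numbers cannot be told apart with confidence. Compound 2 has the higher of the two numbers, but its nearest neighbour, compound 1, sits within the scatter of it.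

The next compound, compound 3 `CNCc1cn(S(=O)(=O)c2cncc(F)c2)c(-c2cccnc2F)c1F`, differs from compound 2 in one place: 5-fluoropyridin-3-yl in place of pyridin-2-yl on a sulfonyl sulfur.

Going by the values given here, the one measured step, the swap of a furan-2-yl for a pyridin-2-yl, bears on this only loosely, since here a pyridin-2-yl is exchanged for a 5-fluoropyridin-3-yl; that earlier step stayed within the scatter. A small rise is expected, with the step from compound 2 to compound 3 estimated at a number 0.26 log units higher from compound 2 to compound 3 (within the scatter). Compound 3 is therefore expected to give about 0.7 in this assay, between 0.3 and 1.1.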

Compound 3, distribution coefficient: 0.83
For compound 3 the middle estimate is 0.13 log units below the measured one; the measured number falls inside the stated range.
By their numbers in this assay, from the lowest: compounds 1 and 2 (each within the scatter of the next); then compound 3.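

For the compounds shown here, at this place on the sulfonyl sulfur, the choice of aromatic ring can move the number in this assay by more than the scatter: 5-fluoropyridin-3-yl in place of pyridin-2-yl gives a number 0.39 log units higher from compound 2 to compound 3 (beyond the scatter), whereas the only earlier step stayed within the scatter. The same group in place of furan-2-yl gives a number 0.63 log units higher from compound 1 to compound 3 (beyond the scatter), so compound 3 stands clear of both earlier compounds, while those two remain within the scatter of each other. No further measurement accompanies these numbers that could give a reason for the rise.

The step from compound 2 to compound 3 changes two things at once, adding a fluorine and changing how the pyridine ring is attached to the sulfonyl sulfur, and the compounds shown leave open how much of the step belongs to each, which a plain pyridin-3-yl at this place would help to separate. Also open, as far as these compounds go, is how the number would respond to a group of a different kind on the sulfonyl sulfur, such as an amine like morpholine or a short alkyl chain.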